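Methoxy-to-hydrogen step on the fused core and clearance

This account rests on a few compounds, and the source may have more. Where it says the series, first, only, none or still open, it means among the compounds named here.

Three compounds of the series have been run in an ADME assay on microsomes from liver (Homo sapiens) for metabolic stability; a higher number here means faster removal of the compound, a lower number slower removal. Compound 1 `COc1ccn2c(-c3ccc(NC(=O)c4ccc([N+](=O)[O-])o4)cc3C)cnc2c1` gives 48.8 mL.min-1.g-1 in this assay. Compound 2 `COc1ccn2c(-c3ccc(NC(=O)c4ccc([N+](=O)[O-])o4)c(C)c3)cnc2c1` gives 52.6 mL.min-1.g-1 in this assay, and compound 3 `Cc1cc(-c2cnc3ccccn23)ccc1NC(=O)c1ccc([N+](=O)[O-])o1` gives 57.2 mL.min-1.g-1 in this assay. All three numbers lie within the scatter of one another, so no order among them is claimed. Compound 1 and compound 2 are built from the same atoms joined differently; the difference between the two cores is not broken down here.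

One structural change has been measured once. Compound 3 differs from compound 2 by hydrogen in place of methoxy on an aromatic carbon, and the resulting step is a 1.1-fold higher number from compound 2 to compound 3 (0.04 log units; within the scatter).

Compound 4 `Cc1cc(NC(=O)c2ccc([N+](=O)[O-])o2)ccc1-c1cnc2ccccn12` has not yet been measured in this assay. It differs from compound 1 by hydrogen in place of methoxy on an aromatic carbon. The place of this change matches the measured pair word for word, so it is the same change rather than merely the same kind. Among the measured compounds shown here, the expectation for compound 4 rests on compound 1 with its value 48.8 mL.min-1.g-1 and on the single measured step of a 1.1-fold higher number from compound 2 to compound 3 (0.04 log units; within the scatter). For compound 4 the expected step is a 1.1-fold higher number from compound 1 to compound 4 (0.04 log units; within the scatter), set beside the earlier one. Compound 4 is therefore estimated at 53 mL.min-1.g-1 in this assay, with a range from 32 mL.min-1.g-1 to 85 mL.min-1.g-1. One measured occurrence is a thin base, so the range is kept wide.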

Compound 4, intrinsic clearance in microsomes: 51 mL.min-1.g-1
Estimate against measurement, compound 4: 1.0-fold (0.02 log units) above, and the stated range covers the measured number.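

In this assay, putting hydrogen in place of methoxy on an aromatic carbon of the core of compound 1 gives a 1.0-fold higher number from compound 1 to compound 4 (0.02 log units; within the scatter), so this step is again small enough to lie within the scatter. Set beside the earlier occurrence, the step carries over between the two cores without a readable difference: the same change on two cores in this assay, a 1.1-fold higher number (0.04 log units; within the scatter) from compound 2 to compound 3 and a 1.0-fold higher number (0.02 log units; within the scatter) from compound 1 to compound 4, 1.0-fold (0.02 log units) apart, within the scatter of two such steps

Among the compounds shown here, this agreement is between two steps that each lie within the scatter, so it shows only that the change has no readable effect on clearance on either core, not that an effect of a given size transfers from one core to another, and two cores are too few to support a rule for the wider series.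

The compounds shown carry only methoxy or hydrogen at this place, so it remains open whether an amine, a carboxylic acid or a longer alkoxy chain such as ethoxy there would give a step beyond the scatter. If such a step appears on one core, whether it repeats on the other is also open, and that would be the first real test of transfer in this series.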